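The source may report more compounds than this note shows. Statements on the series, on what has been measured and on what is new or still open speak of the compounds shown alone.

Working notes on the series.

Compound 3 `CCCCCCCC/C=C\CCCCCCC(=O)c1nnn(C)n1` carries a methylated tetrazole on the carbonyl of a long unsaturated chain; in an assay on isolated protein for inhibition of Fatty-acid amide hydrolase 1 (Homo sapiens) (a lower number here means a stronger inhibitor, a higher number a weaker inhibitor), compound 3 gives 65 nM, the second highest of the three numbers recorded. Its nearest neighbour is compound 2 `CCCCCCCCCCCCCCCCCC(=O)C(F)(F)F`, the trifluoromethyl ketone, which in this assay gives 240 nM; the furthest is compound 1 `CCCCCCCC/C=C\CCCCCCC(=O)c1nc2cnccc2o1`, which gives 7.2 nM and is the strongest inhibitor measured. Among the measured compounds shown here, the one step that was measured at the carbonyl position, a 9.0-fold higher number from compound 1 to compound 3 (0.96 log units; beyond the scatter), is a modest loss on going to the smaller four-heteroatom ring.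

Compound 4 `CCCCCCCC/C=C\CCCCCCC(=O)c1nc2cccnc2o1` reverses that kind of change: a group of 9 heavy atoms (6 carbon, 2 nitrogen, 1 oxygen; one five-membered aromatic ring with 2 hetero atoms, one six-membered aromatic ring with 1 hetero atom) in place of a group of 6 heavy atoms (2 carbon, 4 nitrogen; one five-membered aromatic ring with 4 hetero atoms), on a carbonyl carbon. For the measured compounds named here, the entering group shares the atom count and ring pattern of the group in compound 1 without being identical to it, so the step measured from compound 1 to compound 3 is the only direct guide. Run backwards it points to a gain of roughly that size, although a second bicyclic arrangement need not match the first one exactly. The expected step is an 8.1-fold lower number from compound 3 to compound 4 (0.91 log units; beyond the scatter), a drop in this assay back toward the level of compound 1. Compound 4 is therefore estimated at 8 nM, within a range of 2.5 nM to 30 nM.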

Compound 4, inhibition constant: 11 nM
Beside the measured number, compound 4's estimate is 1.4-fold (0.14 log units) below it; low and high end bracket the measured number.
By their numbers in this assay, from the lowest: compounds 1 and 4 (each within the scatter of the next); then compound 3; then compound 2.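

Replacing 2-methyl-2H-tetrazol-5-yl on the carbonyl carbon gives a 5.9-fold lower number from compound 3 to compound 4 (0.77 log units; beyond the scatter) in this assay and shows that the advantage over that group is not tied to the single arrangement of atoms in compound 1. The two entering groups share their atom count and ring pattern, yet the comparison gives a 1.5-fold higher number from compound 1 to compound 4 (0.18 log units; within the scatter) and so does not separate them, which means this position tolerates at least this one rearrangement of the same atoms without a readable change in the number. No measurement on these compounds accounts for either step.

The compounds shown do not tell whether the six-membered ring or its nitrogen is needed for the gain, a question that an unfused oxazol-2-yl group or a benzoxazol-2-yl group with no nitrogen in the six-membered ring would address on the same carbonyl carbon. On these data alone, it also remains open whether a carboxylic acid on the six-membered ring would be tolerated, and whether the gap between these groups persists on a shorter saturated chain.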